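Shortening the amine-bearing chain in a 4-aminoquinoline amidine series

A few compounds are considered here, and "the series" means these few. Any claim that something is new, unique, unknown or untested is made for them only; others in the source may bear on it.

Compound 3, `CCN(CC)CCCCN/C(C)=N\c1ccnc2cc(Cl)ccc12`, gives 2.68 ug/mL in an ADME assay on HepG2 cells (Homo sapiens) for cytotoxicity, read by MTT assay, with a stated time of 48 h (a lower number here means a stronger inhibitor, a higher number a weaker inhibitor), the lowest of the two numbers in hand. Among the compounds with values here, compound 1, `CCN(CC)CCCCN/C(=N\c1ccnc2cc(Cl)ccc12)C(C)C`, gives 5.01 ug/mL, and the step of a 1.9-fold lower number from compound 1 to compound 3 (0.27 log units; within the scatter) is the only change measured against a neighbour. Compound 2, `C/C(=N/c1ccnc2cc(Cl)ccc12)NC1CCN(C)CC1`, reaches only a limit of > 30.3 ug/mL in this assay. Compound 4, `CCN(CC)CCN/C(C)=N\c1ccnc2cc(Cl)ccc12`, is not yet measured; it differs from compound 3 by diethylamino in place of 2-(diethylamino)ethyl on a saturated chain carbon, two bonds along the chain from an amine nitrogen. Within the data shown here, no measured step tests this kind of change, so the one step available, small as it is, gives no pointer either way, and no movement beyond the scatter is expected. Compound 4 is therefore estimated at 4 ug/mL, within 1.5 ug/mL to 12 ug/mL, a step of a 1.5-fold higher number from compound 3 to compound 4 (0.17 log units; within the scatter).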

Compound 4, half-maximal inhibitory concentration: 1.32 ug/mL
Compound 4: the middle estimate sits 3.0-fold (0.48 log units) above what was measured; the whole stated range lies above it.
By their numbers in this assay, from the lowest: compound 4; then compounds 3 and 1 (each within the scatter of the next). At a limit, above all of these: compound 2.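

In this assay, within the data shown here, diethylamino in place of 2-(diethylamino)ethyl on a saturated chain carbon, two bonds along the chain from an amine nitrogen, gives a 2.0-fold lower number from compound 3 to compound 4 (0.31 log units; beyond the scatter), a modest change and the first step between these chain-bearing compounds printed beyond the scatter. With 2-(diethylamino)ethyl in place of 1-methylpiperidin-4-yl on an amine nitrogen, the result is an at least 22-fold lower number from compound 2 to compound 4 (1.36 log units; beyond the scatter), a large step. The reading for compound 2 is a limit, not a number: the limit of > 30.3 ug/mL in this assay, at which 1 of the 4 values shown sits.

The compounds shown leave open whether a chain shorter again would lower the number further. They also leave open whether a pyrrolidine or a morpholine in place of the diethylamino group would keep it there.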